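Thiophen-3-yl in Place of a Dimethylpyrazolyl Group

This account rests on a few compounds, and the source may have more. Where it says the series, first, only, none or still open, it means among the compounds named here.

Compound 1 `CCOC(=O)c1cnc(C(C)(C)C)nc1NN1C(=O)C=C(C)C1=O`: 1000 nM
Compound 2 `CCOC(=O)c1cnc(SC)nc1NN1C(=O)C=C(C)C1=O`: 200 nM
Compound 3 `CCOC(=O)c1cnc(-n2nc(C)cc2C)nc1NN1C(=O)C=C(C)C1=O`: 10000 nM

These three compounds share one core and differ only in the group on the aromatic carbon between two ring nitrogen atoms. In a functional assay on Jurkat cells for inhibition of nuclear factor NF-kappa-B complex (Homo sapiens) (on this read-out higher numbers stand for weaker inhibition and lower numbers for stronger inhibition), compound 3 gives the highest number of the three: the step is a 10-fold higher number from compound 1 to compound 3 (1.00 log units; beyond the scatter) and a 50-fold higher number from compound 2 to compound 3 (1.70 log units; beyond the scatter). Compound 4 `CCOC(=O)c1cnc(-c2ccsc2)nc1NN1C(=O)C=C(C)C1=O` is not yet measured; its change is thiophen-3-yl in place of 3,5-dimethyl-1H-pyrazol-1-yl on an aromatic carbon. Among the measured compounds shown here, both measured steps onto compound 3 exchanged a small group for the dimethylpyrazolyl ring and gave higher numbers, so taking that ring away again is expected to lower the number, though no measured compound carries a thiophene and the size is uncertain. Compound 4 is therefore estimated at 2000 nM, between 400 nM and 10000 nM, which would mean a 5.0-fold lower number from compound 3 to compound 4 (0.70 log units; beyond the scatter).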

Compound 4, half-maximal inhibitory concentration: 100 nM
For compound 4 the middle estimate is 20-fold (1.30 log units) above the measured one, outside the stated range (below it).
By their numbers in this assay, from the lowest: compounds 4 and 2 (each within the scatter of the next); then compound 1; then compound 3.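

In this assay a five-membered aromatic ring at this position does not by itself give a high number, as thiophen-3-yl in place of 3,5-dimethyl-1H-pyrazol-1-yl gives a 100-fold lower number from compound 3 to compound 4 (2.00 log units; beyond the scatter) here. Thiophen-3-yl also improves on tert-butyl, with a 10-fold lower number from compound 1 to compound 4 (1.00 log units; beyond the scatter) as the step, while a 2.0-fold lower number from compound 2 to compound 4 (0.30 log units; within the scatter) means that it and methylsulfanyl cannot be told apart. Nothing available explains why the two rings differ so widely.

Still open, from the compounds shown here alone, is whether a pyrazole without its two methyl groups would behave like the thiophene. Going by these compounds, it is also open how a phenyl ring or an amine would compare at this position.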